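The compounds below may be only part of what the source reports. "The series", "measured", "known", "first", "only" and "open" are said of these compounds alone.

Compound 1 `O=C1CSC(c2cccc(O)c2)N1CCN1CCCCC1`: 100%
Compound 2 `O=C1CSC(c2ccc(O)cc2)N1CCN1CCCCC1`: 87%
Compound 3 `O=C1CSC(c2ccc(F)cc2)N1CCN1CCCCC1`: 73%

Of the compounds shown here, three built on the same core have been tested in an ADME assay on Vero cells (Chlorocebus sabaeus) for cytotoxicity, read by neutral red uptake, tested at 197 ug/mL; a higher number here means a weaker effect of the compound at the concentration tested, a lower number a stronger effect. Compound 1 stands highest of the three: the number drops a number 13 percentage points lower from compound 1 to compound 2 (beyond the scatter) when the hydroxy moves to the other position on the phenyl ring, and drops further a number 27 percentage points lower from compound 1 to compound 3 (beyond the scatter) when a fluoro replaces it there.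

Compound 4 `COc1cccc(C2SCC(=O)N2CCN2CCCCC2)c1` has not been measured. It differs from compound 1 by methyl in place of hydrogen on an oxygen on an aromatic ring. Going by the values given here, no measured step swaps a hydrogen for a methyl on an oxygen, so the nearest guide is the change from compound 2 to compound 3, where fluoro in place of hydroxy on an aromatic carbon gave a number 14 percentage points lower from compound 2 to compound 3 (beyond the scatter); that step also takes away the hydroxy, as the present change does. The two steps starting from compound 1 move the hydroxy rather than remove it and bear less directly. A modest downward step is therefore expected in this assay, though a flat result within the scatter cannot be ruled out. Compound 4 is estimated at 87%, between 70% and 100%, which means an expected step of a number 13 percentage points lower from compound 1 to compound 4 (beyond the scatter).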

Compound 4, a percentage reported as activity, at one concentration (the size of the read-out at that concentration, not a potency): 66%
The estimate for compound 4 lay 21 percentage points above the measured number; the whole stated range lies above it.
By their numbers in this assay, from the lowest: compounds 4 and 3 (each within the scatter of the next); then compound 2; then compound 1.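

In this assay, going by these compounds alone, the change from hydroxy to methoxy leaves the oxygen in place on the aromatic ring and adds only a methyl in place of its hydrogen, yet it gives a large step (a number 34 percentage points lower from compound 1 to compound 4 (beyond the scatter)), whereas the earlier steps were modest. So at this position, keeping the oxygen is not enough to keep the high number of compound 1: replacing the hydrogen on that oxygen with a methyl is enough on its own to shift the result beyond the scatter. Nothing available explains why this small change has such an effect.

From the compounds shown here alone, whether an ethyl on the same oxygen, or an amine in place of the hydroxy, would give a number closer to compound 1 or to compound 4 remains open. Going by these compounds, it is also open whether the same methyl on the hydroxy of compound 2 would produce a step of similar size.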